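Taking the methoxy off compound 2

The source may hold more compounds than are shown below. What is called first, only, known or untested is meant among the compounds shown, and "the series" means these compounds.

In a functional assay on CCRF-CEM cells (Homo sapiens) for cytotoxicity (a lower number here means that less compound is tolerated, a higher number that more compound is tolerated), compound 1 `Cc1cccc2c1OP(=O)(OCC1CCC(n3cnc4c(O)ncnc43)O1)OC2` gives 58000 nM and compound 2 `COc1ccc2c(c1)COP(=O)(OCC1CCC(n3cnc4c(N)ncnc43)O1)O2` gives 87000 nM as half-maximal cytotoxic concentrations. These two numbers lie within the usual scatter of each other, so compound 2 stands level with compound 1 and neither can be ranked over the other.

Compound 3 `Nc1ncnc2c1ncn2C1CCC(COP2(=O)OCc3ccccc3O2)O1` has not yet been measured. It departs from compound 2 by a single change hydrogen in place of methoxy on an aromatic carbon in which hydrogen takes the place of methoxy on an aromatic carbon. Going by the values given here, no measured pair isolates this change, so the data offer no direct size for it. Among the compounds with values here, the only guide is that the two numbers so far sit close together, with compound 1 at 58000 nM and compound 2 at 87000 nM in the same region of this assay readings. A small expected move, the estimated 1.2-fold lower number from compound 2 to compound 3 (0.09 log units; within the scatter) and no more, would stay inside the scatter, and no firm direction is expected. The estimate for compound 3 is 70000 nM with an expected range from 28000 nM to 170000 nM once the measurement is made.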

Compound 3, half-maximal cytotoxic concentration: 93000 nM
Compound 3: the middle estimate sits 1.3-fold (0.12 log units) below what was measured; measured number inside the range.
By their numbers in this assay, from the lowest: compounds 1, 2 and 3 (each within the scatter of the next).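

Read in this assay, the change of methoxy to hydrogen on this aromatic carbon gives a 1.1-fold higher number from compound 2 to compound 3 (0.03 log units; within the scatter), and this pair supplies the first direct measure of a single change in the series. On this six-membered aromatic ring of carbon only, part of a fused or bridged system of two rings, removing methoxy therefore leaves the cytotoxic concentration level with that of compound 2, so this assay does not tell the two compounds apart. Nothing measured here bears on why the two compounds stand level.

This single pair cannot show whether other groups on the same carbon, such as an amine, a carboxylic acid or a longer chain like butoxy, would also stay within the scatter of compound 3 or would move the number beyond it. Going by these compounds alone, it also leaves open whether the same exchange of methoxy for hydrogen would stay as small on a different core, since compound 1 differs from compound 2 and compound 3 in more than one place and offers no matching pair.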